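Trimming the sulfur substituent of compound 1 to an ethynyl group

A few compounds are considered here, and "the series" means these few. Any claim that something is new, unique, unknown or untested is made for them only; others in the source may bear on it.

For the measured compounds named here, compound 1 `Cc1cc(N2CC[C@@H](C)[C@@H](N(C)c3ncnc4[nH]ccc34)C2)n2nc(SCC3CC3)nc2n1` is the only member of this small set with a measured number: in a functional assay on HGC-27 cells (Homo sapiens) for inhibition, read by MTT assay, with a stated time of 72 h (on this read-out lower numbers stand for stronger inhibition and higher numbers for weaker inhibition), compound 1 gives 21400 nM. Compound 2 `Cc1cc(N2CC[C@@H](C)[C@@H](N(C)c3ncnc4[nH]ccc34)C2)n2nc(SCc3nc4ccccc4[nH]3)nc2n1` reaches only the limit of this assay, > 100000 nM. Compound 3 `Cc1cc(N2CC[C@@H](C)[C@@H](N(C)c3ncnc4[nH]ccc34)C2)n2nc(SCc3ccc(F)c(Cl)c3)nc2n1` likewise reaches only the limit of this assay, > 100000 nM. Both changes grow the group on the saturated chain carbon bound to the sulfur: an at least 4.6-fold higher number from compound 1 to compound 2 (0.66 log units; beyond the scatter), and an at least 4.6-fold higher number from compound 1 to compound 3 (0.66 log units; beyond the scatter). The weakening in both cases is tied to the limit of > 100000 nM in this assay, at which 2 of the 3 values shown sit, so its true size is not known.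

Compound 4 `C#CSc1nc2nc(C)cc(N3CC[C@@H](C)[C@@H](N(C)c4ncnc5[nH]ccc45)C3)n2n1` goes the other way, shrinking the group: ethynyl in place of cyclopropylmethyl on a sulfur. Neither measured step covers a smaller substituent on this sulfur, so they give no direct guidance; they only show that enlarging it cost activity. On that basis compound 4 is expected to stay near compound 1, with a step of a 1.2-fold higher number from compound 1 to compound 4 (0.07 log units; within the scatter) in this assay, and an estimated value of 25000 nM (range 8000 nM to 90000 nM).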

Compound 4, half-maximal inhibitory concentration: 35100 nM
Compound 4: middle estimate off by 1.4-fold (0.15 log units), on the low side; the measured number falls inside the stated range.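

Shrinking the group from cyclopropylmethyl to ethynyl, which removes the three-membered ring and brings in a triple bond, does not move the result in this assay beyond the scatter: a 1.6-fold higher number from compound 1 to compound 4 (0.21 log units; within the scatter). Activity on this sulfur therefore does not depend on the cyclopropylmethyl group, and the two larger groups separate from ethynyl, with an at least 2.8-fold lower number from compound 3 to compound 4 (0.45 log units; beyond the scatter) and an at least 2.8-fold lower number from compound 2 to compound 4 (0.45 log units; beyond the scatter). From the compounds shown here alone, the true size of these two steps is unknown, since both rest on a limit: the limit of > 100000 nM in this assay, at which 2 of the 4 values shown sit.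

Compound 1 gives 21400 nM. Going by these compounds, it remains open whether any group on this sulfur can give a clearly lower number than compound 1, for instance a methyl, an aminoethyl chain or a short chain ending in a carboxylic acid. The step between the two larger groups cannot be read, as both of their values are limits.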